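Notes on the step from compound 3 to compound 4

The source may report more compounds than this note shows. Statements on the series, on what has been measured and on what is new or still open speak of the compounds shown alone.

Measured so far:
- compound 1 `N#CC1=C(N)Oc2c(c3nc4ccccc4nc3c3ccccc23)C12C(=O)N(Cc1cnnn1-c1ccc(Cl)cc1)c1ccccc12`: > 50000 nM (a limit of the assay)
- compound 2 `Cc1ccc(-n2nncc2CN2C(=O)C3(C(C#N)=C(N)Oc4c3c3nc5ccccc5nc3c3ccccc43)c3ccccc32)c(C)c1`: > 50000 nM (a limit of the assay)
- compound 3 `N#CC1=C(N)Oc2c(N)cc3nc4ccccc4nc3c2C12C(=O)N(Cc1cnnn1-c1ccccc1Cl)c1ccccc12`: > 50000 nM (a limit of the assay)

All three values in an ADME assay on L02 cells (Homo sapiens) for antiproliferative activity, read by MTT assay, with a stated time of 48 h (on this read-out higher numbers stand for weaker inhibition and lower numbers for stronger inhibition), are limits, not numbers. Within the data shown here, the only step between two measured compounds, a step that the two limits leave unreadable from compound 1 to compound 2, is left unreadable by the two limits. Compound 3 stands at the limit of > 50000 nM in this assay, at which 3 of the 3 values shown sit, so its position among the measured compounds is known only as a limit, not as a ranking.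

Compound 4 `N#CC1=C(N)Oc2c(N)cc3nc4ccccc4nc3c2C12C(=O)N(Cc1cnnn1-c1ccc([N+](=O)[O-])cc1[N+](=O)[O-])c1ccccc12` differs from compound 3 by 2,4-dinitrophenyl in place of 2-chlorophenyl on an aromatic nitrogen. Among the measured compounds shown here, no measured step touches a nitro-bearing aryl group, and the single step in hand gives no readable size, so no size or direction can be taken from the data for this assay.

Compound 4 is therefore expected to sit at the same limit, with an estimated step that the limit leaves unreadable from compound 3 to compound 4 of no readable size. Compound 4 is estimated at 60000 nM in this assay, in the range 30000 nM to 150000 nM, most likely reported again as a limit.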

Compound 4, half-maximal inhibitory concentration: 22800 nM
Compound 4: the middle estimate sits 2.6-fold (0.42 log units) above what was measured; the measured number lies below the stated range.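

In this assay, the aryl group on the aromatic nitrogen proves able to move the read-out: 2,4-dinitrophenyl in place of 2-chlorophenyl gives an at least 2.1-fold lower number from compound 3 to compound 4 (0.34 log units; beyond the scatter). Among these compounds, this is the first readable step at this position, and the other step between measured compounds, on the core of compound 1, cannot be read. Among the values shown, only compound 4 gives a number rather than a limit: the limit of > 50000 nM in this assay, at which 3 of the 4 values shown sit.

As far as these compounds go, compound 3 gives > 50000 nM, which is a limit, so the full size of the step stays open. The nitro groups enter together as the chlorine leaves, so the compounds shown do not tell which part of the change matters, or whether a single nitro group, an amine or a carboxylic acid on the same phenyl ring would act alike.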